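The source may hold more compounds than are shown below. What is called first, only, known or untested is meant among the compounds shown, and "the series" means these compounds.

All three measured compounds share one core and differ only in the group attached at a saturated ring carbon of a five-membered non-aromatic ring with one nitrogen, part of a fused system of two rings, two ring bonds from the ring nitrogen. Compound 1 `O=C1Nc2c(ccc(F)c2F)C1(c1ccc(O)cc1)c1cccs1` carries thiophen-2-yl there and in a functional assay on PC-3 cells (Homo sapiens) for cytotoxicity, read by WST assay, with a stated time of 72 h (a lower number here means a stronger inhibitor, a higher number a weaker inhibitor), compound 1 gives 0.3 nM. Compound 2 `O=C1Nc2c(ccc(F)c2F)C1(c1ccncc1)c1ccc(O)cc1` carries pyridin-4-yl and in this assay compound 2 gives 110 nM. Compound 3 `O=C1Nc2c(ccc(F)c2F)C1(c1ccc(O)cc1)C1CCCC1` carries cyclopentyl and in this assay compound 3 gives 8.2 nM, the second highest of the three numbers, with a 27-fold higher number from compound 1 to compound 3 (1.44 log units; beyond the scatter) and a 13-fold lower number from compound 2 to compound 3 (1.13 log units; beyond the scatter).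

Compound 4 `O=C1Nc2c(ccc(F)c2F)C1(Cc1ccccc1)c1ccc(O)cc1` is not yet measured. The change is benzyl in place of cyclopentyl on a saturated ring carbon. Going by the values given here, no measured step swaps cyclopentyl for benzyl, so the nearest guidance comes from the steps that end at compound 3: an aromatic ring bound directly to this carbon gave a far lower number in compound 1 than cyclopentyl, while another aromatic ring gave a far higher number in compound 2. A benzyl group places an aromatic ring one carbon further out, so a moderate move is expected, more likely downward than upward. Compound 4 is therefore estimated at 5 nM, within 1 nM to 30 nM, an expected step of a 1.6-fold lower number from compound 3 to compound 4 (0.21 log units; within the scatter).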

Compound 4, half-maximal inhibitory concentration: > 1000 nM
Compound 4: no number, only a limit; the forecaster's own chance of this, stated with the estimate: 2%; middle value at least 200-fold (2.30 log units) away from the limit.
By their numbers in this assay, from the lowest: compound 1; then compound 3; then compound 2. At a limit, above all of these: compound 4.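

In this assay, compound 4 gives a limit and not a number, so its true value is unknown and its steps are minimum sizes: the limit of > 1000 nM in this assay, at which 1 of the 4 values shown sits.

Even so, this is the largest change seen at this position, with an at least 120-fold higher number from compound 3 to compound 4 (2.08 log units; beyond the scatter), an at least 9.0-fold higher number from compound 2 to compound 4 (0.95 log units; beyond the scatter), and an at least 3300-fold higher number from compound 1 to compound 4 (3.52 log units; beyond the scatter). Until now, each group at this saturated ring carbon was a ring bound directly to it, and those compounds spanned a wide range while all still gave a number, whereas benzyl, with a carbon between the ring and the core, gives only the limit, so how a ring is attached here can matter as much as which ring it is.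

These compounds cannot separate the effect of the linking carbon from that of the phenyl ring itself, and a phenyl group bound directly to this carbon would help to tell the two apart. On these data alone, it also remains open whether a longer chain such as 2-phenylethyl, or a small group such as an amine, would be tolerated at this position.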